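Four phosphodiester dithiocarbamates tested on prostate cancer cells

A few compounds are considered here, and "the series" means these few. Any claim that something is new, unique, unknown or untested is made for them only; others in the source may bear on it.

Compound 1 `CCCCCCCCOP(=O)(O)OCCSC(=S)N1CCCCC1` joins an octyl chain through a phosphate to a dithiocarbamate bearing a piperidin-1-yl group. In a functional assay on PC-3 cells (Homo sapiens) for inhibition, read by MTT assay, with stated times of 18 h and 4 h (a higher number here means a weaker inhibitor, a lower number a stronger inhibitor), compound 1 gives only a limit of the assay, > 100000 nM. Compound 2 `CCCCCCCCOP(=O)(O)OCCSC(=S)N1CCN(C)CC1` differs from it by 4-methylpiperazin-1-yl in place of piperidin-1-yl on a thiocarbonyl carbon. In this assay compound 2 likewise gives only a limit, > 100000 nM. The step that the two limits leave unreadable from compound 1 to compound 2 therefore cannot be sized. Compound 3 `CCCCCCOP(=O)(O)OCCSC(=S)N1CCCCC1` differs from compound 1 in its core by hydrogen in place of ethyl on a saturated chain carbon, six bonds along the chain from an oxygen on an unsaturated carbon. In this assay compound 3 again gives only a limit, > 100000 nM. The step that the two limits leave unreadable from compound 1 to compound 3 is equally unreadable. Every value shown sits at the limit of > 100000 nM in this assay, at which 3 of the 3 values shown sit.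

Compound 4 `CCCCCCOP(=O)(O)OCCSC(=S)N1CCN(C)CC1` is not yet measured. It differs from compound 3 by 4-methylpiperazin-1-yl in place of piperidin-1-yl on a thiocarbonyl carbon, the same change already made between the first two compounds, at a place described in identical words. Compound 4 is therefore expected to give 100000 nM in this assay, most likely again as a limit rather than a number. That expectation means an estimated step of a number no higher from compound 3 to compound 4 (the limit leaves the size open), and it rests on compound 3, whose limit is > 100000 nM, together with the unreadable size of a step that the two limits leave unreadable from compound 1 to compound 2.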

Compound 4, half-maximal inhibitory concentration: > 100000 nM
Compound 4: a limit, no number; the forecaster's own chance of this, stated with the estimate: 85%; the middle value sits exactly at the limit.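

In this assay compound 4 gives > 100000 nM, a limit and not a number. The steps to compound 4 from compound 3 and from compound 2 cannot be read, because every value is a limit: the limit of > 100000 nM in this assay, at which 4 of the 4 values shown sit. The compounds shown leave open whether 4-methylpiperazin-1-yl in place of piperidin-1-yl, or the shorter chain, changes inhibition at all.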